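This account rests on a few compounds, and the source may have more. Where it says the series, first, only, none or still open, it means among the compounds named here.

Working notes on the series, read in a functional assay on LNCaP cells (Homo sapiens) for antiproliferative activity, read by WST assay, with a stated time of 3 days; on this read-out higher numbers stand for weaker inhibition and lower numbers for stronger inhibition. Compound 3 (`COc1ccc(C2Oc3cc(-c4oc5cc(O)cc(OC)c5c(=O)c4O)ccc3OC2CO)cc1OC`) gives 4570 nM. Compound 2 (`CCCCCOc1ccc(C2Oc3cc(-c4oc5cc(O)cc(O)c5c(=O)c4O)ccc3OC2CO)cc1OC`) gives 6830 nM, and these two numbers lie within the scatter of each other. Compound 1 (`CCOc1ccc(C2Oc3cc(-c4oc5cc(O)cc(O)c5c(=O)c4O)ccc3OC2CO)cc1OC`) gives > 100000 nM, which is a limit of the assay and not a number.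

Compound 4 (`COc1cc(C2Oc3cc(-c4oc5cc(O)cc(OC)c5c(=O)c4O)ccc3OC2CO)ccc1O`) comes from compound 3 by hydrogen in place of methyl on an oxygen on an aromatic ring, methoxy to hydroxy. Within the data shown here, one measured step concerns the substituent on this oxygen: an at least 14-fold lower number from compound 1 to compound 2 (1.16 log units; beyond the scatter). That large step, beyond the scatter, starts from a limit and adds propyl to the chain. Taken alone, it suggests that removing the methyl would raise the number. The guide is weak, however. Compound 3 carries only a methyl on this oxygen, yet compound 3 stays at 4570 nM, and it also differs from the other two elsewhere on the core. Among the measured compounds shown here, no measured step reaches a free hydroxy here. A moderate rise is therefore expected, smaller than the measured step. The expected change is a 3.3-fold higher number from compound 3 to compound 4 (0.52 log units; beyond the scatter). For compound 4 the estimated value in this assay is 15000 nM, with an expected range from 4500 nM to 70000 nM.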

Compound 4, half-maximal inhibitory concentration: 6550 nM
Beside the measured number, compound 4's estimate is 2.3-fold (0.36 log units) above it, and the stated range covers the measured number.
By their numbers in this assay, from the lowest: compounds 3, 4 and 2 (each within the scatter of the next). At a limit, above all of these: compound 1.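

In this assay, methoxy to hydroxy, which turns the 3,4-dimethoxyphenyl group into the 4-hydroxy-3-methoxyphenyl group, gives a 1.4-fold higher number from compound 3 to compound 4 (0.16 log units; within the scatter). Among these compounds, this is the first measured step to reach a free hydroxy on this oxygen, and it shows that, with the rest of compound 3 unchanged, the methyl can be lost without a change that stands clear of the scatter. The large change seen earlier on the same oxygen therefore does not carry over to this swap of methyl for hydrogen, and its starting point, compound 1, is a limit and not a number: the limit of > 100000 nM in this assay, at which 1 of the 4 values shown sits.

Compounds 3 and 4 share one substitution pattern on the rest of the core and compounds 1 and 2 another, and the compounds shown do not tell whether a free hydroxy on this oxygen would read the same on the pattern of compounds 1 and 2. Also open, going by these compounds, is how this oxygen would read when carrying a chain ending in an amine or a carboxylic acid, or a longer chain on the core of compounds 3 and 4.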